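The compounds below may be only part of what the source reports. "The series", "measured", "known", "first", "only" and "open" are said of these compounds alone.

Compound 1 `Fc1ccc(-n2cc(COc3ccccc3-c3nc4ccccc4s3)nn2)cc1Cl` and compound 2 `Brc1ccc(-c2cc(COc3ccccc3-c3nc4ccccc4s3)on2)cc1` share one core and differ in the group carried on it. In an ADME assay on MCF-10A cells (Homo sapiens) for cytotoxicity, read by MTT assay, with a stated time of 24 h (a higher number here means a weaker inhibitor, a lower number a stronger inhibitor), compound 1 gives 26300 nM and compound 2 gives 29200 nM, two values within the scatter of each other, so neither stands apart. Compound 3 `FC(F)(F)c1cccc(-n2cc(COc3ccccc3-c3nc4ccccc4s3)nn2)c1` differs from compound 1 by one change: 3-(trifluoromethyl)phenyl in place of 3-chloro-4-fluorophenyl on an aromatic nitrogen. For the measured compounds named here, no pair of measured compounds shows this change, so no measured step exists for it. In this assay the step is expected to be none beyond the scatter, a 1.0-fold lower number from compound 1 to compound 3 (0.00 log units; within the scatter). Compound 3 is therefore estimated at 26000 nM, within a range from 12000 nM to 55000 nM.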

Compound 3, half-maximal inhibitory concentration: 31100 nM
Compound 3: middle estimate off by 1.2-fold (0.08 log units), on the low side; low and high end bracket the measured number.
By their numbers in this assay, from the lowest: compounds 1, 2 and 3 (each within the scatter of the next).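

For the compounds shown here, this gives the first measured step for this position: a 1.2-fold higher number from compound 1 to compound 3 (0.07 log units; within the scatter) in this assay. Going by these compounds alone, exchanging 3-chloro-4-fluorophenyl for 3-(trifluoromethyl)phenyl on the aromatic nitrogen therefore gives no change that can be told from the scatter, though this is only one exchange between two substituted phenyl groups. Nothing measured here bears on why the two compounds read alike. The compounds shown leave open what a group of a different kind at this position, such as an amine or a carboxylic acid on the phenyl ring, would do.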